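A few compounds are considered here, and "the series" means these few. Any claim that something is new, unique, unknown or untested is made for them only; others in the source may bear on it.

Measured compounds:
Compound 1, `COc1ccc(N(C)c2nc(C)nc3ccccc23)cc1OCCN`, in a functional assay on HCT-116 cells (Homo sapiens) for inhibition, read by MTT assay, with a stated time of 48 h (a lower number here means a stronger inhibitor, a higher number a weaker inhibitor), gives 198 nM.
Compound 2, `C[Se]c1ccc(N(C)c2nc(C3CC3)nc3ccccc23)cc1`, in this assay gives 15 nM.

Of the two measured compounds, compound 2 has the lowest number; its nearest neighbour is compound 1, whose value stands well beyond the scatter of repeated measurements, so compound 2 is the stronger inhibitor of the two in this assay. Going by the values given here, no single-change step connects the two measured compounds, so the two values alone say what the pair shows.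

Compound 3, `CN(c1ccc([Se]C#N)cc1)c1nc(C2CC2)nc2ccccc12`, has not yet been measured in this assay. It differs from compound 2 in one place: cyano in place of methyl on a selenium. Cyano in place of methyl on a selenium whose other neighbour is aromatic carbon leaves the rest of compound 2 untouched.

Among the compounds with values here, nothing among the measured compounds bears on a change of this kind, so the expectation rests on compound 2 alone. The step from compound 2 to compound 3 is expected to be modest and towards a higher number, that is a 2.7-fold higher number from compound 2 to compound 3 (0.43 log units; beyond the scatter), though a result within the scatter of compound 2 is also possible. Compound 3 is estimated to give 40 nM in this assay, with a range from 8 nM to 200 nM.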

Compound 3, half-maximal inhibitory concentration: 62 nM
For compound 3 the middle estimate is 1.6-fold (0.19 log units) below the measured one; measured number inside the range.
By their numbers in this assay, from the lowest: compound 2; then compound 3; then compound 1.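

In this assay, putting cyano in place of methyl on a selenium whose other neighbour is aromatic carbon gives a 4.1-fold higher number from compound 2 to compound 3 (0.62 log units; beyond the scatter), a modest step but one beyond the scatter, so the methyl form is the stronger inhibitor of this pair. Going by these compounds alone, this is the first single-change step, and it shows that this position responds to a change of the group on selenium, though the effect here is a loss of inhibition and not its disappearance: compound 3 still gives 62 nM with the rest of the structure untouched. No measurement is at hand that explains why the number rises with this change, so the step stands as an observation only.

With a single step at this position, the compounds shown cannot tell whether the number follows any trend in the group on selenium, so a longer chain such as ethyl, a benzyl group or an amine-bearing chain in that place remains an open case. They also leave open how much the selenium itself contributes, since neither sulfur nor oxygen in its place appears among them.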